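A few compounds are considered here, and "the series" means these few. Any claim that something is new, unique, unknown or untested is made for them only; others in the source may bear on it.

Measured in a functional assay on HCT-116 cells (Homo sapiens) for antiproliferative activity, read by MTT assay, with a stated time of 24 h; on this read-out higher numbers stand for weaker inhibition and lower numbers for stronger inhibition:

- Compound 1 `c1ccc(-c2noc(-c3ccncc3)n2)cc1`: > 1000000 nM, a limit
- Compound 2 `COc1ccc(-c2noc(C3CCCN3)n2)cc1OC1CCCC1`: 185000 nM
- Compound 3 `COc1ccc(-c2noc(Cc3c[nH]c4ccccc34)n2)cc1OC1CCCC1`: > 1000000 nM, a limit

Among these three, compound 2 alone gives an actual number, 185000 nM. The results for compound 1 and compound 3 are limits. Within the data shown here, the set therefore contains (the limit of > 1000000 nM in this assay, at which 2 of the 3 values shown sit), and no step between measured compounds can be stated.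

Compound 4 `COc1ccc(-c2noc(-c3ccc(F)cc3)n2)cc1OC1CCCC1` keeps the core of compound 2 but carries 4-fluorophenyl in place of pyrrolidin-2-yl on an aromatic carbon.

Among the measured compounds shown here, the only compound with pyrrolidin-2-yl is also the only one with a number, compound 2 at 185000 nM, so weaker inhibition is expected once that group is gone. Three compounds cannot establish this as a pattern, and a result that is only a limit would not be a surprise in this assay. The expected change is modest, a 2.4-fold higher number from compound 2 to compound 4 (0.39 log units; beyond the scatter). For compound 4 the estimated value is 450000 nM, within an expected range of 120000 nM to 1000000 nM.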

Compound 4, half-maximal inhibitory concentration: 210000 nM
For compound 4 the middle estimate is 2.1-fold (0.33 log units) above the measured one, within the range that was stated.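

In this assay, placing 4-fluorophenyl in place of pyrrolidin-2-yl on this aromatic carbon gives a 1.1-fold higher number from compound 2 to compound 4 (0.06 log units; within the scatter). The position therefore takes either group without a change that can be told from the scatter, although a five-membered non-aromatic ring with a hydrogen-bond donor and acceptor leaves and a six-membered aromatic ring of carbon only enters. Among these compounds, compound 2 is thus no longer the only compound with a number, and pyrrolidin-2-yl is not needed for one in this pair.

Steps to compound 1 and compound 3 cannot be read, since each gives only a limit of the assay: the limit of > 1000000 nM in this assay, at which 2 of the 4 values shown sit. Whether a carboxylic acid, an open-chain amine or a 4-methoxyphenyl at this carbon would give a value like these remains open.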